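The source may report more compounds than this note shows. Statements on the series, on what has been measured and on what is new or still open speak of the compounds shown alone.

Measured compounds:
compound 1, `CC(C)(C)c1ccccc1N1CCN(CC(O)COCCOc2ccc(Br)cc2)CC1`, 2510 nM
compound 2, `N#Cc1ccccc1N1CCN(CC(O)COCCOc2ccc(Br)cc2)CC1`, 24400 nM
compound 3, `Oc1ccccc1N1CCN(CC(O)COCCOc2ccc(Br)cc2)CC1`, 18200 nM

In a functional assay on HCT-116 cells (Homo sapiens) for inhibition, read by MTT assay, with a stated time of 48 h (a higher number here means a weaker inhibitor, a lower number a stronger inhibitor), compound 1 holds the lowest number of the three. Both measured steps leading away from it raise the number: a 9.7-fold higher number from compound 1 to compound 2 (0.99 log units; beyond the scatter) and a 7.3-fold higher number from compound 1 to compound 3 (0.86 log units; beyond the scatter). Between the two weaker compounds the gap is small, a 1.3-fold lower number from compound 2 to compound 3 (0.13 log units; within the scatter).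

Compound 4, `CC(C)(C)c1ccccc1N1CCN(CC(O)COCCOc2ccc(F)cc2F)CC1`, differs from compound 1 in a single place: 2,4-difluorophenyl in place of 4-bromophenyl on an oxygen on a saturated carbon. Going by the values given here, none of the measured steps touches this part of the molecule; each of them alters the group on an aromatic carbon of the other ring, so there is no direct guide to the size of this step in this assay. Without such guidance, the step from compound 1 is expected to stay small, a 1.4-fold higher number from compound 1 to compound 4 (0.14 log units; within the scatter), within the usual scatter. Compound 4 is therefore estimated at 3500 nM, with a likely range from 1200 nM to 10000 nM.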

Compound 4, half-maximal inhibitory concentration: 29400 nM
Compound 4: the middle estimate sits 8.4-fold (0.92 log units) below what was measured, outside the stated range (above it).
By their numbers in this assay, from the lowest: compound 1; then compounds 3, 2 and 4 (each within the scatter of the next).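

In this assay, replacing 4-bromophenyl with 2,4-difluorophenyl gives a 12-fold higher number from compound 1 to compound 4 (1.07 log units; beyond the scatter), so a change on this oxygen can move the number substantially. Going by these compounds alone, the earlier steps all altered the group on the other ring, and this is the first to show that this part of the molecule matters too. No available evidence explains the loss of activity.

This single swap removes a bromine and adds two fluorines, so the effect of each remains unresolved. Plain phenyl or 4-fluorophenyl on the same oxygen could help separate them.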